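The compounds below may be only part of what the source reports. "The series", "measured", "known", "first", "only" and "open" are said of these compounds alone.

Three related compounds have been measured so far in a functional assay on DU-145 cells (Homo sapiens) for inhibition, read by trypan blue exclusion, with a stated time of 96 h; on this read-out lower numbers stand for stronger inhibition of growth and higher numbers for weaker inhibition of growth. In that test compound 3 (`Cc1ccc(CS/C(=C/c2ccc(Cl)c([N+](=O)[O-])c2)C(=O)c2ccc(C(=O)O)cc2)cc1`) gives 1000 nM and stands level with compound 1 (`Cc1ccc(CS/C(=C/c2ccc(F)c([N+](=O)[O-])c2)C(=O)c2ccc(Cl)c([N+](=O)[O-])c2)cc1`), which gives 1000 nM as well. Together these two hold the lowest number of the three. Compound 2 (`O=C(O)c1ccc(C(=O)/C(=C\c2ccc(F)c([N+](=O)[O-])c2)SCc2ccc(Cl)cc2)cc1`) gives 50000 nM and that much higher number lies well beyond the usual scatter of repeated measurements.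

The next compound is compound 4 (`Cc1ccc(CS/C(=C/c2ccc(F)c([N+](=O)[O-])c2)C(=O)c2ccc(C(=O)O)cc2)cc1`). It differs from compound 3 in one place, with fluoro in place of chloro on an aromatic carbon, ortho to a nitro group (fluoro in place of chloro on an aromatic carbon). This is a swap of a single atom, so only a modest step is expected, towards a higher number and weaker inhibition of growth. The measured compounds give limited guidance. The 4-fluoro-3-nitrophenyl group occurs in compound 1 at 1000 nM and also in compound 2 at 50000 nM, so a much higher result cannot be ruled out and the range is wider on the upper side. The expected change is a 2.0-fold higher number from compound 3 to compound 4 (0.30 log units; within the scatter) in this assay. Compound 4 is estimated at 2000 nM and the range from 500 nM to 20000 nM should hold the expected result.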

Compound 4, concentration for 50% growth inhibition: 1000 nM
The estimate for compound 4 lay 2.0-fold (0.30 log units) above the measured number, and the stated range covers the measured number.
By their numbers in this assay, from the lowest: compounds 1, 3 and 4 (each within the scatter of the next); then compound 2.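

In this assay the change from 4-chloro-3-nitrophenyl to 4-fluoro-3-nitrophenyl gives no change at the digits printed from compound 3 to compound 4 (within the scatter), so at this place, ortho to a nitro group, the test does not tell the two halogens apart. The 4-fluoro-3-nitrophenyl group is also carried by compound 2, and a single swap elsewhere in the molecule, with chloro going out and methyl coming in, gives a 50-fold lower number from compound 2 to compound 4 (1.70 log units; beyond the scatter), which ties the high number of compound 2 to that one place and not to the fluoro group. A much larger swap, 4-carboxyphenyl in place of 4-chloro-3-nitrophenyl on a carbonyl carbon, gives no change at the digits printed from compound 1 to compound 4 (within the scatter), and no measured evidence is available to explain why these steps differ so much in size.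

Going by these compounds, whether bromo or a plain hydrogen at the place ortho to the nitro group would also leave the number in line with these compounds stays open. On these data alone, it is also open whether the large step between chloro and methyl would recur with an amide or an amine in place of the carboxylic acid.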